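The source may hold more compounds than are shown below. What is called first, only, known or untested is meant among the compounds shown, and "the series" means these compounds.

Compound 2, `COc1cc(-c2nn(-c3cccc(NC(=O)Nc4ccc(Cl)c(Cl)c4)c3)cc2-c2ccncc2)ccc1Cl`, gives 2270 nM in a functional assay on OVCAR-3 cells (Homo sapiens) for inhibition, read by sulforhodamine B assay, with a stated time of 48 h; a higher number here means a weaker inhibitor of growth, a lower number a stronger inhibitor of growth. Among the three measured compounds it holds the lowest number, but its nearest neighbour, compound 3 (`O=C(Nc1cccc(-n2cc(-c3ccncc3)c(-c3ccc(Cl)c(O)c3)n2)c1)Nc1ccc(Cl)c(Cl)c1`), gives 3150 nM, and the step of a 1.4-fold higher number from compound 2 to compound 3 (0.14 log units; within the scatter) lies within the scatter, so the two cannot be ordered. Only compound 1 (`O=C(Nc1cccc(-n2cc(-c3ccncc3)c(-c3ccc(Cl)c(O)c3)n2)c1)Nc1cccc(C(F)(F)F)c1`), which gives 6130 nM, stands apart from compound 2 beyond the scatter.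

Compound 4 (`COc1cc(-c2nn(-c3cccc(NC(=O)c4ccc(Cl)c(C(F)(F)F)c4)c3)cc2-c2ccncc2)ccc1Cl`) differs from compound 2 in one place: 4-chloro-3-(trifluoromethyl)phenyl in place of (3,4-dichlorophenyl)amino on a carbonyl carbon. Among the compounds with values here, no measured pair covers this change. The closest step is a 1.9-fold lower number from compound 1 to compound 3 (0.29 log units; within the scatter), which exchanges two substituted phenyl groups on the amide-type nitrogen and stays within the scatter, suggesting that such aryl exchanges move the numbers little. The loss of the (3,4-dichlorophenyl)amino group itself has no measured precedent among these compounds. Compound 4 is therefore expected to give a number close to that of compound 2, with the step of a 1.5-fold higher number from compound 2 to compound 4 (0.19 log units; within the scatter) estimated to stay roughly within the scatter, though with wide uncertainty. Compound 4 is estimated at 3500 nM, expected to fall between 1000 nM and 12000 nM.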

Compound 4, concentration for total growth inhibition: 19800 nM
Beside the measured number, compound 4's estimate is 5.7-fold (0.75 log units) below it, and the stated range ends below it.
By their numbers in this assay, from the lowest: compounds 2, 3 and 1 (each within the scatter of the next, the first and the last beyond it); then compound 4.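

In this assay, within the data shown here, this change at the carbonyl carbon whose other neighbour is the amide-type nitrogen is the first single change to move the number beyond the scatter, with an 8.7-fold higher number from compound 2 to compound 4 (0.94 log units; beyond the scatter). The earlier exchange of aryl groups on the amide-type nitrogen, a 1.9-fold lower number from compound 1 to compound 3 (0.29 log units; within the scatter), stayed within the scatter, so that step does not carry over to this position, where (3,4-dichlorophenyl)amino, which counts one hydrogen-bond donor, gives way to 4-chloro-3-(trifluoromethyl)phenyl, which counts none. Nothing measured here accounts for the rise.

The step alters both the link to the aromatic ring and the ring's substituents, so the compounds shown leave open whether the amino nitrogen, the trifluoromethyl group or both lie behind it, a question that the pairing of 4-chloro-3-(trifluoromethyl)phenylamino or of 3,4-dichlorophenyl with the same carbonyl carbon could settle. On these data alone, it also remains open how a methylene link or a longer carbon chain in place of the amino nitrogen would read at this position.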